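Nitrophenyl exchange carried across two related cores

This account rests on a few compounds, and the source may have more. Where it says the series, first, only, none or still open, it means among the compounds named here.

Measured compounds in a functional assay on MCF7 cells (Homo sapiens) for cytotoxicity, read by MTT assay, with a stated time of 72 h; on this read-out higher numbers stand for weaker inhibition and lower numbers for stronger inhibition:
compound 1 `CCOC(=O)C1=C(C)NC(=O)NC1c1cn(C(=O)CNc2ccc([N+](=O)[O-])cc2C)c2ccccc12` gives 50 ug/mL
compound 2 `CCOC(=O)C1=C(C)NC(=S)NC1c1cn(C(=O)CNc2ccc([N+](=O)[O-])cc2C)c2ccccc12` gives 48 ug/mL
compound 3 `CCOC(=O)C1=C(C)NC(=O)NC1c1cn(C(=O)CNc2ccccc2[N+](=O)[O-])c2ccccc12` gives 40 ug/mL

The difference between the core of compound 1 and the core of compound 2 is not broken down here. Compound 3 arises from compound 1 by a single change, (2-nitrophenyl in place of 2-methyl-4-nitrophenyl on an amine nitrogen), and on that change the read-out moved by a 1.3-fold lower number from compound 1 to compound 3 (0.10 log units; within the scatter). The same kind of change, applied to the core of compound 2, gives compound 4 `CCOC(=O)C1=C(C)NC(=S)NC1c1cn(C(=O)CNc2ccccc2[N+](=O)[O-])c2ccccc12`, which has not yet been measured; the change is 2-nitrophenyl in place of 2-methyl-4-nitrophenyl on an amine nitrogen, and the surroundings of the place are the same in both pairs. Compound 1 and compound 2 give numbers in this assay that sit within the scatter of each other, so nothing shows the second core responding differently from the first. Because the earlier step read a 1.3-fold lower number from compound 1 to compound 3 (0.10 log units; within the scatter), the matching step is expected to be a 1.3-fold lower number from compound 2 to compound 4 (0.10 log units; within the scatter). Compound 4 is therefore estimated at 38 ug/mL, with a range from 24 ug/mL to 60 ug/mL.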

Compound 4, half-maximal inhibitory concentration in the MCF7 assay: 550 ug/mL
The estimate for compound 4 lay 14-fold (1.16 log units) below the measured number; measured number outside the range, above it.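

In the MCF7 assay, 2-nitrophenyl in place of 2-methyl-4-nitrophenyl on the amine nitrogen gives an 11-fold higher number from compound 2 to compound 4 (1.06 log units; beyond the scatter), and the change does not carry from one core to the other: the same change on two cores in the MCF7 assay, a 1.3-fold lower number (0.10 log units; within the scatter) from compound 1 to compound 3 and an 11-fold higher number (1.06 log units; beyond the scatter) from compound 2 to compound 4, 14-fold (1.16 log units) apart, beyond the scatter of two such steps. In a physicochemical assay for lipophilicity (a higher number here means a more lipophilic compound, a lower number a more polar compound), compound 2 gives 3.34 and compound 4 gives 2.88. On the core of compound 2 the lipophilicity also falls, but this is a measured companion of the weaker inhibition and is not shown to be its cause: the measured partition coefficient of compound 2, 3.34, and of compound 4, 2.88, a number 0.46 log units lower (beyond the scatter). With one matched pair on each core, these compounds show that the outcome of this exchange depended on the core here, but they give no general rule for the series and cannot assign the result to one part of the exchanged group.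

From the compounds shown here alone, it remains open whether the sensitivity seen on the core of compound 2 extends to other groups on the amine nitrogen, such as a phenyl ring carrying an amine or a carboxylic acid instead of the nitro group. Going by these compounds, it is also open whether a longer chain in place of the ethyl ester would leave this core dependence intact.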